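This account rests on a few compounds, and the source may have more. Where it says the series, first, only, none or still open, it means among the compounds named here.

Working notes on the diaryl urea and thiourea series.

Compound 1 `CCC1(CC)CC(CC)(CC)c2cc(NC(=O)Nc3ccc(C(F)(F)F)cc3)ccc2O1` is the reference point for the first core; in a functional assay on A2780 cells (Homo sapiens) for inhibition, with a stated time of 72 h (a lower number here means a stronger inhibitor, a higher number a weaker inhibitor), compound 1 gives 2000 nM. Compound 2 `CCC1(CC)CC(CC)(CC)c2cc(NC(=O)Nc3ccc([N+](=O)[O-])cc3)ccc2O1` keeps that core and differs from compound 1 only by nitro in place of trifluoromethyl on an aromatic carbon; in this assay compound 2 gives 2090 nM. Among the compounds with values here, the step of a 1.0-fold higher number from compound 1 to compound 2 (0.02 log units; within the scatter), so within the first core the exchange of trifluoromethyl for nitro leaves the read-out essentially where it was.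

Compound 3 `CC1(C)CCOc2ccc(NC(=S)Nc3ccc(C(F)(F)F)cc3)cc21` belongs to a second core, and it also carries a thiourea rather than a urea. In this assay compound 3 gives 5500 nM, the highest number of the three measured compounds, with its steps to compound 1 and compound 2 both beyond the scatter. The difference between the core of compound 3 and the core of compound 1 is not broken down here.

Compound 4 `CC1(C)CCOc2ccc(NC(=S)Nc3ccc([N+](=O)[O-])cc3)cc21` is the not yet measured partner of compound 3 and differs from it by nitro in place of trifluoromethyl on an aromatic carbon. This is the same change as that from compound 1 to compound 2, made on the second core. Because the step of a 1.0-fold higher number from compound 1 to compound 2 (0.02 log units; within the scatter) lay within the scatter, a flat step is expected here as well, with compound 4 estimated to sit close to compound 3, that is no change at the digits printed from compound 3 to compound 4 (within the scatter). Compound 4 is estimated at 5500 nM, with a range of 2700 nM to 11000 nM.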

Compound 4, half-maximal inhibitory concentration: 6400 nM
Estimate against measurement, compound 4: 1.2-fold (0.07 log units) below, within the range that was stated.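

In this assay, the exchange of trifluoromethyl for nitro on the second core gives a 1.2-fold higher number from compound 3 to compound 4 (0.07 log units; within the scatter), and the two cores agree on this change: the same change on two cores in this assay, a 1.0-fold higher number (0.02 log units; within the scatter) from compound 1 to compound 2 and a 1.2-fold higher number (0.07 log units; within the scatter) from compound 3 to compound 4, 1.1-fold (0.05 log units) apart, within the scatter of two such steps. Within these two pairs, then, the change carries from the core of compound 1 to the core of compound 3 as a flat step, on the urea of the first pair and on the thiourea of the second alike. This does not show that the change would stay flat on any further core or in any other read-out, and it says nothing about why the step is flat, as two flat steps in a single cell assay give no explanation of their own.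

The compounds shown leave open whether the flat step extends beyond these two groups, for example to a nitrile, an amine or a carboxylic acid at the same place on the aromatic ring. Within the data shown here, they also leave open how much of the higher numbers of the second pair belongs to the core and how much to the thiourea, as no pair here changes one of these alone.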